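The source may report more compounds than this note shows. Statements on the series, on what has been measured and on what is new or still open speak of the compounds shown alone.

Compound 1 (`CN(O)/C=C\C(=O)c1ccc(Cl)cc1`) reads > 10000 nM in a functional assay on cells (Homo sapiens) for inhibition (on this read-out lower numbers stand for stronger inhibition and higher numbers for weaker inhibition), which is a limit of the assay and not a number. Compound 2 (`CN(O)/C=C\C(=O)c1ccc(F)cc1`) gives 5500 nM in this assay. Within the data shown here, the only measured step is an at least 1.8-fold lower number from compound 1 to compound 2 (0.25 log units; that floor lies within the scatter), with fluoro in place of chloro on an aromatic carbon. That step lies at a different place from the change considered here, so it sets no size for it.

Compound 3 (`O=C(/C=C\N(O)Cc1ccccc1)c1ccc(Cl)cc1`) differs from compound 1 by phenyl in place of hydrogen on a saturated chain carbon bound to an amine nitrogen. Among the measured compounds shown here, no measured step covers this place. Compound 2 at 5500 nM shows only that this series can give a number in this assay, so a modest move to a lower number is expected. A reading for compound 3 that is again a limit of the assay remains possible. The expected change is an at least 2.0-fold lower number from compound 1 to compound 3 (0.30 log units; that floor lies within the scatter), an estimate with wide uncertainty. For compound 3 the estimate is 5000 nM, with an expected range of 1000 nM to 20000 nM.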

Compound 3, half-maximal inhibitory concentration: 2100 nM
Estimate against measurement, compound 3: 2.4-fold (0.38 log units) above; the range from low to high includes it.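

Phenyl in place of hydrogen on a saturated chain carbon bound to an amine nitrogen is the first change read at this place, and in this assay it gives an at least 4.7-fold lower number from compound 1 to compound 3 (0.67 log units; beyond the scatter). The earlier step concerned only the halogen on the aromatic carbon, whereas this one shows that the chain carbon on the amine nitrogen accepts a phenyl and that, with the chloro group kept, the series gives a number rather than a limit. The size of this step is only a floor, as compound 1 stands at a limit of the assay: the limit of > 10000 nM in this assay, at which 1 of the 3 values shown sits.

From the compounds shown here alone, whether the aromatic ring itself is needed stays open, since cyclohexyl or a plain propyl chain at the same place would test this. Also open, going by these compounds, is whether phenyl gives a comparable step on the fluoro compound 2.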